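Methoxy for methyl on the aryl arm of a guanidine series

The source may hold more compounds than are shown below. What is called first, only, known or untested is meant among the compounds shown, and "the series" means these compounds.

Two guanidines with the same imidazolylpropyl arm have been measured. Compound 1 `N=C(NCCCc1c[nH]cn1)NCCC(c1ccccc1)c1ccccn1` carries an unsubstituted phenyl ring beside the pyridyl; in a functional assay on muscle tissue for agonist activity at histamine H2 receptor (Cavia porcellus) (on this read-out lower numbers stand for lower potency and higher numbers for higher potency (the scale is a negative logarithm)), compound 1 gives 7.37. Compound 2 `Cc1ccc(C(CC/N=C(\N)NCCCc2c[nH]cn2)c2ccccn2)cc1` carries a 4-methylphenyl in the same position; in this assay compound 2 gives 7.15. Compound 2 stands as the lower of the two numbers, but the gap to compound 1 lies inside the usual scatter, so the two cannot be ordered.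

Compound 3 `COc1ccc(C(CC/N=C(\N)NCCCc2c[nH]cn2)c2ccccn2)cc1` is not yet measured. It differs from compound 2 by methoxy in place of methyl on an aromatic carbon, that is, a methoxy in place of methyl on an aromatic carbon, placed para to a large group on the six-membered carbon-only ring. Among the compounds with values here, no measured pair in the set shows this exchange, so nothing here sets its size. The two measured compounds suggest that substitution on this ring moves the read-out little, and the expectation is for no step beyond the scatter, with an expected step of a number 0.05 log units lower from compound 2 to compound 3 (within the scatter).

For compound 3 the estimate in this assay is 7.1, with an expected range from 6.6 to 7.6.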

Compound 3, negative logarithm of the half-maximal effective concentration: 7
Beside the measured number, compound 3's estimate is 0.10 log units above it; the range from low to high includes it.
By their numbers in this assay, from the lowest: compounds 3, 2 and 1 (each within the scatter of the next, the first and the last beyond it).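

In this assay the exchange of 4-methylphenyl for 4-methoxyphenyl gives a number 0.15 log units lower from compound 2 to compound 3 (within the scatter), so this place on the ring accepts a methoxy, with its added oxygen and hydrogen-bond acceptor, without a step that stands clear of the scatter. The ends of the set now lie beyond the scatter of each other, with compound 3 at 7 and compound 1 at 7.37, while compound 2 lies within the scatter of both, so a substituent at this place may matter, but the methyl and methoxy compounds cannot be told apart. Nothing measured on hand accounts for the size of this step or of that wider gap.

From the compounds shown here alone, it remains open whether a group of another kind at this place, such as an amine, a carboxylic acid or a chlorine, would give a step clearly beyond the scatter from compound 2. Going by these compounds, it is also open whether a longer chain on the oxygen, such as ethoxy or propoxy, would stay within the scatter of compound 3.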